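Fluoro-methyl aryl replacing dichloroaryl on the shared core

A few compounds are considered here, and "the series" means these few. Any claim that something is new, unique, unknown or untested is made for them only; others in the source may bear on it.

Three analogues with the shared core carry different aryl groups. Compound 1 `COc1cc(-n2cnc3ccc(-c4ccc(Cl)cc4)cc32)cc(OC)c1OC` bears a 4-chlorophenyl, compound 2 `COc1cc(-n2cnc3ccc(-c4ccccc4)cc32)cc(OC)c1OC` a phenyl, compound 3 `COc1cc(-n2cnc3ccc(-c4ccc(Cl)cc4Cl)cc32)cc(OC)c1OC` a 2,4-dichlorophenyl. In a functional assay on MCF7 cells (Homo sapiens) for antiproliferative activity, read by MTT assay, with a stated time of 72 h (on this read-out lower numbers stand for stronger inhibition and higher numbers for weaker inhibition), compound 1 gives 1320 nM, compound 2 gives 2290 nM, and compound 3 gives 5420 nM, the highest of the three numbers. The steps are a 1.7-fold higher number from compound 1 to compound 2 (0.24 log units; within the scatter), a 4.1-fold higher number from compound 1 to compound 3 (0.61 log units; beyond the scatter) and a 2.4-fold higher number from compound 2 to compound 3 (0.37 log units; beyond the scatter), so within this set the 2,4-dichlorophenyl is associated with the weakest inhibition, while the single chloro versus hydrogen difference between compound 1 and compound 2 stays inside the scatter.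

Compound 4 `COc1cc(-n2cnc3ccc(-c4ccc(C)cc4F)cc32)cc(OC)c1OC` is not yet measured. It differs from compound 3 in one place: 2-fluoro-4-methylphenyl in place of 2,4-dichlorophenyl on an aromatic carbon. The relevant comparisons are the two that lead into compound 3, a modest rise in each case, and they concern chloro against hydrogen, not fluoro or methyl. For the measured compounds named here, no measured step tells how a second 2,4-disubstituted aryl compares with the first, so in this assay the step is expected to be small, with a slight lean toward a lower number, a 1.5-fold lower number from compound 3 to compound 4 (0.19 log units; within the scatter). Compound 4 is estimated at 3500 nM, within a range of 1400 nM to 8500 nM.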

Compound 4, half-maximal inhibitory concentration: 56 nM
Beside the measured number, compound 4's estimate is 63-fold (1.80 log units) above it; measured number outside the range, below it.
By their numbers in this assay, from the lowest: compound 4; then compounds 1 and 2 (each within the scatter of the next); then compound 3.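

In this assay, for the compounds shown here, the aryl group on this aromatic carbon of the shared core has far more influence than the earlier compounds showed: the change to 2-fluoro-4-methylphenyl gives a 97-fold lower number from compound 3 to compound 4 (1.99 log units; beyond the scatter), so carrying two substituents does not in itself tie an aryl group to weak inhibition. The same group also separates clearly from the phenyl, with a 41-fold lower number from compound 2 to compound 4 (1.61 log units; beyond the scatter), and from the 4-chlorophenyl, with a 24-fold lower number from compound 1 to compound 4 (1.37 log units; beyond the scatter), both far larger than any step among the three earlier compounds, which makes compound 4 the strongest inhibitor of the four. No measurement shown here bears on why this exchange of aryl groups has so large an effect.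

Whether the fluoro or the methyl of the 2-fluoro-4-methylphenyl accounts for the step stays open, as the two enter together and neither appears without the other in the compounds shown. Also open, from the compounds shown here alone, is how this position responds to an aryl group carrying an amine, a carboxylic acid or a longer chain such as butyl in place of the methyl.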